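The compounds below may be only part of what the source reports. "The series", "measured", "known", "first", "only" and "open" are said of these compounds alone.

Measured so far:
- compound 1 `COc1cc(OCc2cccc(-c3ccc(C#N)cn3)c2)c2cc(-c3cn4nc(OC)sc4n3)oc2c1`: 464 ng.h/mL
- compound 2 `COc1cc(OCc2cccc(-c3ccc(OC)nc3)c2)c2cc(-c3cn4nc(OC)sc4n3)oc2c1`: 1800 ng.h/mL
- compound 3 `CNC(=O)c1ccc(-c2nc(COc3cc(OC)cc4oc(-c5cn6nc(OC)sc6n5)cc34)cs2)cc1`: 21.9 ng.h/mL

In an ADME assay on the whole organism (Rattus norvegicus), at a dose of 2 mg/kg by the oral route (on this read-out higher numbers stand for higher exposure at the dose given and lower numbers for lower exposure), compound 3 gives 21.9 ng.h/mL, the lowest of the three numbers. Compound 1 gives 464 ng.h/mL in this assay and compound 2 gives 1800 ng.h/mL, so both sit well beyond the scatter above compound 3.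

Compound 4 `COc1cc(OCc2csc(-c3ccc(S(C)(=O)=O)cc3)n2)c2cc(-c3cn4nc(OC)sc4n3)oc2c1` has not yet been measured. It differs from compound 3 in one place: methylsulfonyl in place of methylcarbamoyl on an aromatic carbon. Among the measured compounds shown here, the only step measured between two compounds differing in one place is a 3.9-fold higher number from compound 1 to compound 2 (0.59 log units; beyond the scatter), which concerns a change on a different part of the molecule, so it does not speak to the swap of methylcarbamoyl for methylsulfonyl. For the measured compounds named here, no measured pair shows how this assay answers that swap.

With nothing to lean on, the expected step is a 1.8-fold higher number from compound 3 to compound 4 (0.26 log units; within the scatter), a number that may well stay within the scatter of compound 3. Compound 4 is therefore estimated at 40 ng.h/mL, with a range from 8 ng.h/mL to 200 ng.h/mL to cover the uncertainty.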

Compound 4, area under the concentration-time curve: 148 ng.h/mL
Estimate against measurement, compound 4: 3.7-fold (0.57 log units) below; measured number inside the range.
By their numbers in this assay, from the lowest: compound 3; then compound 4; then compound 1; then compound 2.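

In this assay the move from 4-(methylcarbamoyl)phenyl to 4-(methylsulfonyl)phenyl gives a 6.8-fold higher number from compound 3 to compound 4 (0.83 log units; beyond the scatter) and so shows that exposure responds to the group held at this place on the ring. The response appears even though both groups have the same number of heavy atoms and neither carries a net charge, so a swap of equal size can still shift the read-out. The change also replaces the hydrogen-bond donor of the amide, but nothing available explains why exposure moved.

Going by these compounds, it remains open how this assay would answer a primary sulfonamide, a carboxylic acid or an amine at this same place. On these data alone, it also remains open whether methylsulfonyl would bring a similar step on the core of compound 1, where a benzene ring stands in place of the thiazole-type linker.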